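Selenium Swapped for Sulfur on a Second Core

A few compounds are considered here, and "the series" means these few. Any claim that something is new, unique, unknown or untested is made for them only; others in the source may bear on it.

Compound 1 `C[Se]/C(=N\C(=O)c1cc2ccccc2s1)NC(=O)c1cc2ccccc2s1` and compound 3 `CS/C(=N\C(=O)c1cc2ccccc2s1)NC(=O)c1cc2ccccc2s1` are built on one core, while compound 2 `C[Se]/C(=N\C(=O)c1ccco1)NC(=O)c1ccco1` and compound 4 `CS/C(=N\C(=O)c1ccco1)NC(=O)c1ccco1` are built on another; the difference between the two cores is not broken down here. In a functional assay on MCF7 cells (Homo sapiens) for cytotoxicity, read by MTT assay, with a stated time of 72 h (a higher number here means a weaker inhibitor of growth, a lower number a stronger inhibitor of growth), compound 1 gives 5070 nM, compound 3 gives 9510 nM, and compound 2 gives 30 nM, the lowest of the three. The change from compound 1 to compound 3 is a group of 2 heavy atoms (1 carbon, 1 sulfur; no ring) in place of a group of 2 heavy atoms (1 carbon, 1 selenium; no ring), on a carbon with a double bond to nitrogen, and it made a 1.9-fold higher number from compound 1 to compound 3 (0.27 log units; within the scatter). Compound 4 carries the same change on the other core: a group of 2 heavy atoms (1 carbon, 1 sulfur; no ring) in place of a group of 2 heavy atoms (1 carbon, 1 selenium; no ring), on a carbon with a double bond to nitrogen. The step from compound 2 to compound 4 is expected to be of a similar size, a 1.8-fold higher number from compound 2 to compound 4 (0.26 log units; within the scatter). Resting on the earlier step of a 1.9-fold higher number from compound 1 to compound 3 (0.27 log units; within the scatter), which stayed within the scatter, compound 4 is estimated at 55 nM in this assay, with a likely range from 15 nM to 250 nM.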

Compound 4, concentration for 50% growth inhibition: 56100 nM
For compound 4 the middle estimate is 1000-fold (3.01 log units) below the measured one; measured number outside the range, above it.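

In this assay the exchange of the selenium-bearing group for methylsulfanyl gave a 1900-fold higher number from compound 2 to compound 4 (3.27 log units; beyond the scatter) and so counts as a large step on this core. The change therefore did not carry over in size from one core to the other: the same change on two cores in this assay, a 1.9-fold higher number (0.27 log units; within the scatter) from compound 1 to compound 3 and a 1900-fold higher number (3.27 log units; beyond the scatter) from compound 2 to compound 4, 1000-fold (3.00 log units) apart, beyond the scatter of two such steps.
This shows that a step that stayed small on one core cannot be relied on for the other in this series, but two pairs give no rule for further cores and do not show what in the cores sets the steps apart.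

The compounds shown leave open how the exchange behaves when a longer chain such as ethyl takes the place of the methyl on selenium and on sulfur. They also leave open how it behaves on a core carrying an amine or a carboxylic acid.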